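Chloro for fluoro: what to expect in cell toxicity

A few compounds are considered here, and "the series" means these few. Any claim that something is new, unique, unknown or untested is made for them only; others in the source may bear on it.

Measured so far:
- compound 1 `O=c1ccn(CCOc2ccccc2Oc2cc(Cl)cc3cc(Cl)ccc23)c(=O)[nH]1`: 45000 nM
- compound 2 `N#Cc1ccc2c(Oc3ccccc3OCCn3ccc(=O)[nH]c3=O)cc(F)cc2c1`: > 100000 nM

Both compounds were read in an ADME assay on MT2 cells (Homo sapiens) for cytotoxicity, read by MTT assay; on this read-out higher numbers stand for lower toxicity in this test and lower numbers for higher toxicity in this test. Compound 1 gives a number, 45000 nM. For compound 2 the result is different in kind: the reading of > 100000 nM is a limit of the assay and not a number, so compound 2 sits at the limit of > 100000 nM in this assay, at which 1 of the 2 values shown sits. Compound 2 thus stands no more toxic in this assay than the reach of the test allows to say, while compound 1 stands at a number below that reach.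

Compound 3 `N#Cc1ccc2c(Oc3ccccc3OCCn3ccc(=O)[nH]c3=O)cc(Cl)cc2c1` is not yet measured. It differs from compound 2 in one place: chloro in place of fluoro on an aromatic carbon. Compound 1, which gives 45000 nM, carries chloro groups, whereas compound 2 carries fluoro at the place in question. For compound 2 the reading is only a limit of the assay. On that basis a small step in this assay toward higher toxicity is expected for compound 3, likely within or near the usual scatter, with a real chance that the test again reports only a limit. Compound 3 is estimated at 80000 nM, with a range from 30000 nM to 200000 nM. That estimate means an expected step of an at least 1.2-fold lower number from compound 2 to compound 3 (0.09 log units; that floor lies within the scatter).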

Compound 3, half-maximal cytotoxic concentration: 24000 nM
The estimate for compound 3 lay 3.3-fold (0.52 log units) above the measured number, outside the stated range (below it).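

In this assay, among the compounds shown here, this is the first change read on an otherwise identical structure, and swapping fluoro for chloro at this aromatic carbon gives a clear result: an at least 4.1-fold lower number from compound 2 to compound 3 (0.61 log units; beyond the scatter), so in this pair the chloro compound is the more toxic in this test. The true size of that step cannot be fixed, because compound 2 gives only a limit of the assay and not a number: the limit of > 100000 nM in this assay, at which 1 of the 3 values shown sits. The other one-place change, cyano in place of chloro on an aromatic carbon, gives a 1.9-fold lower number from compound 1 to compound 3 (0.27 log units; within the scatter), so with chloro kept at the place where compound 2 has fluoro, this second swap cannot be told apart from repeat-to-repeat noise.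

The compounds shown cover only fluoro and chloro at this place, so they leave open what a bromo group, a methoxy group or an amine would do there. They also give no reason for the step, and they cannot tell whether the same exchange would have a similar effect on a different core.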